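The source may report more compounds than this note shows. Statements on the series, on what has been measured and on what is new or still open speak of the compounds shown alone.

The series rests on a shared core that carries two 3-hydroxyphenyl groups and one further aromatic group. Compound 1 `Oc1cccc(-c2cc(-c3cccs3)cc(-c3cccc(O)c3)n2)c1` bears a thiophen-2-yl group, and in a functional assay on DU-145 cells (Homo sapiens) for cytotoxicity, read by CCK-8 assay (a higher number here means a weaker inhibitor, a lower number a stronger inhibitor), compound 1 gives 1630 nM. Compound 2 `Oc1cccc(-c2cc(-c3ccoc3)cc(-c3cccc(O)c3)n2)c1` bears a furan-3-yl group instead, and in this assay compound 2 gives 1650 nM. The step of a 1.0-fold higher number from compound 1 to compound 2 (0.01 log units; within the scatter) shows that exchanging one five-membered heteroaryl for another left the number essentially where it was. Within the data shown here, of the two numbers measured so far, compound 2 therefore sits at a value that cannot be told apart from that of compound 1 within the scatter.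

Compound 3 `Oc1cccc(-c2cc(-c3ccccn3)cc(-c3cccc(O)c3)n2)c1` differs from compound 2 in one place: pyridin-2-yl in place of furan-3-yl on an aromatic carbon. Among the measured compounds shown here, the only measured step that bears on this change is the one already described, and it stayed within the scatter. For the measured compounds named here, no measured step covers a move from a five-membered to a six-membered heteroaryl, so the expected step in this assay, no change at the digits printed from compound 2 to compound 3 (within the scatter), is taken as none beyond the scatter, with a wider range to reflect the untested ring size. Compound 3 is estimated at 1650 nM, within a range from 600 nM to 4500 nM.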

Compound 3, half-maximal inhibitory concentration: 3610 nM
Compound 3: middle estimate off by 2.2-fold (0.34 log units), on the low side; measured number inside the range.
By their numbers in this assay, from the lowest: compounds 1 and 2 (each within the scatter of the next); then compound 3.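

At this position, opposite the ring nitrogen, the exchange of one five-membered heteroaryl for another had shown no movement, but the pyridin-2-yl group gives a 2.2-fold higher number from compound 2 to compound 3 (0.34 log units; beyond the scatter) in this assay and likewise a 2.2-fold higher number from compound 1 to compound 3 (0.35 log units; beyond the scatter) in the same read-out. The position is therefore not indifferent to the group it carries: among these three compounds, the one with a six-membered aromatic ring stands apart from the two with five-membered aromatic rings, which remain within the scatter of each other, although both steps are only modest. Nothing at hand accounts for this shift.

The compounds shown leave open whether the higher number goes with the six-membered ring as such or with the place of its ring nitrogen, a question that a phenyl group or a pyridin-4-yl group on the same aromatic carbon would address. They also leave open how far the number would move with a group of a different kind at this position, such as an aminomethyl group or a carboxylic acid.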